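The compounds below may be only part of what the source reports. "The series", "measured", "known", "first", "only" and "open" are said of these compounds alone.

Working notes on the series sharing the core of compound 1 `C=CC(=O)N1C(=O)CC(c2ccc(C(F)(F)F)cc2)Sc2ccccc21`, read in a functional assay on Raji cells (Homo sapiens) for cytotoxicity, read by CCK-8 assay, with a stated time of 24 h; on this read-out lower numbers stand for stronger inhibition and higher numbers for weaker inhibition. Compound 1 gives 47600 nM, compound 2 `C=CC(=O)N1C(=O)CC(c2ccc(OC)cc2)Sc2ccccc21` gives 43300 nM, and compound 3 `C=CC(=O)N1C(=O)CC(c2ccc(Cl)cc2)Sc2ccccc21` gives 18400 nM, the lowest of the three numbers. Between the first two, a 1.1-fold lower number from compound 1 to compound 2 (0.04 log units; within the scatter).

Compound 4 `C=CC(=O)N1C(=O)CC(c2cccs2)Sc2ccccc21` is not yet measured. It has thiophen-2-yl in place of 4-chlorophenyl on a saturated ring carbon, next to the ring sulfur: thiophen-2-yl in place of 4-chlorophenyl on a saturated ring carbon.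

Going by the values given here, no measured step replaces the aromatic ring itself, so the evidence is indirect. All three measured steps change only the group on that ring. The chloro group leaves with this change, and the two steps that bring it in are the nearest guide: a 2.6-fold lower number from compound 1 to compound 3 (0.41 log units; beyond the scatter), and a 2.4-fold lower number from compound 2 to compound 3 (0.37 log units; beyond the scatter). Among the compounds with values here, a move to a higher number in this assay is therefore expected, no larger than those steps and possibly within the scatter. The data hold no thiophene comparison, so the range stays wide. The estimated step is a 1.7-fold higher number from compound 3 to compound 4 (0.24 log units; within the scatter). For compound 4 the estimated value is 32000 nM, with an expected range of 15000 nM to 60000 nM.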

Compound 4, half-maximal inhibitory concentration: 659000 nM
Estimate against measurement, compound 4: 21-fold (1.31 log units) below; measured number outside the range, above it.
By their numbers in this assay, from the lowest: compound 3; then compounds 2 and 1 (each within the scatter of the next); then compound 4.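

In this assay, changing the aromatic ring itself on this saturated ring carbon, next to the ring sulfur, moves the number far more than changing the group carried on the ring: a 36-fold higher number from compound 3 to compound 4 (1.55 log units; beyond the scatter) and a 15-fold higher number from compound 2 to compound 4 (1.18 log units; beyond the scatter), whereas the largest step among the substituted phenyl compounds is a 2.6-fold lower number from compound 1 to compound 3 (0.41 log units; beyond the scatter). Going by these compounds alone, the position therefore does not treat the aromatic ring as interchangeable: thiophen-2-yl, a five-membered aromatic ring with 1 hetero atom, gives a much higher number than either the 4-chlorophenyl or the 4-methoxyphenyl group, and compound 4 has the highest number of the series so far. Nothing available explains this loss, so the size of the step stands as an observation without a cause.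

The compounds shown do not separate the change of ring from the loss of the group on it, since a plain phenyl ring could fall near compound 3 or near compound 4. Also open, on these data alone, is whether a chloro group on the thiophene would bring the number back down, and whether furan-2-yl or pyridinyl would follow compound 4 or the phenyl compounds.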